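A Halogenated Ring on the Sulfonamide Nitrogen

A few compounds are considered here, and "the series" means these few. Any claim that something is new, unique, unknown or untested is made for them only; others in the source may bear on it.

Two related compounds have been measured so far in a functional assay on HeLa cells (Homo sapiens) for inhibition, read by CCK-8 assay, with a stated time of 72 h; a lower number here means a stronger inhibitor, a higher number a weaker inhibitor. In this test, compound 1 (`O=C(/C=C/c1cccnc1)NCCCCCCCc1cccc(S(=O)(=O)Nc2ccccc2)c1`) gives 598 nM, and compound 2 (`Cc1ccc(NS(=O)(=O)c2cccc(CCCCCCNC(=O)/C=C/c3cccnc3)c2)cc1`) gives 38.8 nM. Compound 2 therefore has the lower of the two numbers, which makes it the stronger inhibitor, and its gap to compound 1 lies beyond the usual scatter of repeat measurements. These two compounds differ in more than one place, so their gap says nothing about any single group.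

Compound 3 (`O=C(/C=C/c1cccnc1)NCCCCCCc1cccc(S(=O)(=O)Nc2ccc(F)c(Cl)c2)c1`) keeps the rest of compound 2 and changes one group, with 3-chloro-4-fluorophenyl in place of 4-methylphenyl on a sulfonamide nitrogen. Among the compounds with values here, both groups are a six-membered aromatic ring of carbon only, but no measured pair tests a change at this spot, so the forecast is loose. It starts from compound 2 at 38.8 nM. In this assay, the estimated step, a 1.0-fold higher number from compound 2 to compound 3 (0.01 log units; within the scatter), is expected to stay within the scatter, with no firm direction. For compound 3 the expected value is 40 nM, with an estimated range of 12 nM to 130 nM.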

Compound 3, half-maximal inhibitory concentration: 385 nM
The estimate for compound 3 lay 9.6-fold (0.98 log units) below the measured number, outside the stated range (above it).
By their numbers in this assay, from the lowest: compound 2; then compounds 3 and 1 (each within the scatter of the next).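

In this assay, within the data shown here, putting 3-chloro-4-fluorophenyl in place of 4-methylphenyl on a sulfonamide nitrogen gives a 9.9-fold higher number from compound 2 to compound 3 (1.00 log units; beyond the scatter), the first single change whose effect can be read, and it points toward a weaker inhibitor. Both groups are a six-membered aromatic ring of carbon only, with no hydrogen-bond donors or acceptors, yet they are not interchangeable in this test: the groups carried on the ring at this nitrogen can shift the number well beyond the scatter. No measurement at hand bears on why the number rose.

This one swap removes a methyl group and brings in both a chlorine and a fluorine, so the compounds shown cannot tell which part of the change carries the step, and a ring with only the chlorine or only the fluorine on the same chain would separate these parts. From the compounds shown here alone, it also remains open how a ring bearing a methoxy group or a nitrile, or a pyridine ring, would behave on this nitrogen.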